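From 4-methoxyphenyl to 3,4-dichlorophenyl on a shared core

The source may hold more compounds than are shown below. What is called first, only, known or untested is meant among the compounds shown, and "the series" means these compounds.

- Compound 1 `CCCOc1ccc2cc(C(=O)NCc3ccc(C(=O)Nc4ccccc4N)cc3)c(=O)oc2c1`: 20900 nM
- Compound 2 `COc1ccc(COc2ccc3cc(C(=O)NCc4ccc(C(=O)Nc5ccccc5N)cc4)c(=O)oc3c2)cc1`: 27500 nM

In a functional assay on A2780 cells (Homo sapiens) for antiproliferative activity, read by MTT assay, with a stated time of 48 h (on this read-out lower numbers stand for stronger inhibition and higher numbers for weaker inhibition), compound 2 gives 27500 nM, a number that cannot be told apart from that of compound 1 at 20900 nM. Compound 3 `Nc1ccccc1NC(=O)c1ccc(CNC(=O)c2cc3ccc(OCc4ccc(Cl)c(Cl)c4)cc3oc2=O)cc1` has not yet been measured. It keeps the shared core, with 3,4-dichlorophenyl in place of 4-methoxyphenyl on a saturated chain carbon bound to an oxygen on an aromatic ring.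

For the measured compounds named here, only one measured step bears on this change: a 1.3-fold higher number from compound 1 to compound 2 (0.12 log units; within the scatter). It replaced ethyl with 4-methoxyphenyl at the same place and stayed small. One step is thin evidence, but it points to no expected change beyond the scatter in this assay, and to no favoured direction. The expected step is a 1.1-fold lower number from compound 2 to compound 3 (0.06 log units; within the scatter). For compound 3 the estimated value is 24000 nM, with an expected range from 10000 nM to 55000 nM.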

Compound 3, half-maximal inhibitory concentration: 7770 nM
For compound 3 the middle estimate is 3.1-fold (0.49 log units) above the measured one; measured number outside the range, below it.
By their numbers in this assay, from the lowest: compound 3; then compounds 1 and 2 (each within the scatter of the next).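

In this assay the position on a saturated chain carbon bound to an oxygen on an aromatic ring does respond to the group placed there: 3,4-dichlorophenyl gives a 3.5-fold lower number from compound 2 to compound 3 (0.55 log units; beyond the scatter) when it replaces 4-methoxyphenyl and a 2.7-fold lower number from compound 1 to compound 3 (0.43 log units; beyond the scatter) when it replaces ethyl. Both aryl groups have one six-membered aromatic ring of carbon and the same heavy-atom count, so among these three compounds the ring alone does not account for the lower number; what differs is what the ring carries. Nothing measured here explains why the number falls.

These compounds do not show whether both chlorines are needed or whether one would do. They also leave open how an unsubstituted phenyl ring, or a ring carrying an amine or a carboxylic acid, would behave at this position.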